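The compounds below may be only part of what the source reports. "The series", "measured", "known", "first", "only" and "open" are said of these compounds alone.

Measured so far in a functional assay on RAW264.7 cells (Mus musculus), read by immunoassay, with a stated time of 24 h; a lower number here means a stronger inhibitor, a higher number a weaker inhibitor:
- compound 1 `O=C(Oc1ccc(OCc2ccccc2)cc1)N(Nc1ccccc1)S(=O)(=O)c1ccc(-c2ccccc2)cc1`: 93 nM
- compound 2 `Cc1cc(C)c(S(=O)(=O)N(Nc2ccccc2)C(=O)Oc2ccc(Oc3ccccc3)cc2)c(C)c1`: 177 nM

With only these two values available, compound 2 at 177 nM has just one neighbour, compound 1 at 93 nM. The gap between them lies within the usual scatter of repeated measurements, so the two cannot be told apart in this assay.

The next molecule is compound 3 `Cc1cc(C)c(S(=O)(=O)N(Nc2ccccc2)C(=O)Oc2ccc(OCc3ccccc3)cc2)c(C)c1`, which differs from compound 2 in one place: benzyl in place of phenyl on an oxygen on an aromatic ring. Put simply, the phenoxy group of compound 2 becomes benzyloxy in compound 3.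

For the measured compounds named here, no measured pair shows this change alone, so there is no direct guide to its size. Going by the values given here, the only hint is that compound 1 carries benzyloxy and gives 93 nM. No step beyond the scatter is therefore expected in this assay, and any drift would more likely be towards a lower number.

The estimated step is a 1.4-fold lower number from compound 2 to compound 3 (0.13 log units; within the scatter). For compound 3 the expected value is 130 nM, with an estimated range of 50 nM to 340 nM.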

Compound 3, half-maximal inhibitory concentration: 81.5 nM
The estimate for compound 3 lay 1.6-fold (0.20 log units) above the measured number, and the stated range covers the measured number.
By their numbers in this assay, from the lowest: compounds 3, 1 and 2 (each within the scatter of the next, the first and the last beyond it).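

In this assay, for the compounds shown here, benzyl in place of phenyl on an oxygen on an aromatic ring gives a 2.2-fold lower number from compound 2 to compound 3 (0.34 log units; beyond the scatter) and so provides the first direct reading of this change: a modest step, but one beyond the scatter. At the sulfonyl sulfur, 2,4,6-trimethylphenyl in place of 4-phenylphenyl gives a 1.1-fold lower number from compound 1 to compound 3 (0.06 log units; within the scatter) and shows that, with benzyloxy present in both compounds, these two sulfonyl groups cannot be told apart in this assay on this evidence. Nothing measured here explains the step from phenoxy to benzyloxy.

From the compounds shown here alone, it remains open whether a longer chain, such as phenethyl on the same oxygen, would carry the trend further or reverse it, and whether a small group with no ring, such as methyl, would keep a number of this size. Also open, going by these compounds, is how an amine or a carboxylic acid added to the benzyl group would read in this assay, since a single pair cannot show how far this position tolerates change.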